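Pyridin-2-yl for 4-Methylphenyl on the Ring Amide Nitrogen

A few compounds are considered here, and "the series" means these few. Any claim that something is new, unique, unknown or untested is made for them only; others in the source may bear on it.

Two compounds have numbers in a functional assay on DU-145 cells (Homo sapiens) for cytotoxicity, read by sulforhodamine B assay, with a stated time of 48 h; a higher number here means a weaker inhibitor, a lower number a stronger inhibitor. Compound 1 `COc1cc(OC)cc(N2NC3=CC[C@@H](OC)O[C@@]3(c3ccccc3)CCC2=O)c1` gives 2400 nM in this assay. Compound 2 `CO[C@@H]1CC=C2N(c3ccc(C)cc3)C(=O)C[C@]2(c2ccccc2)O1` gives 4400 nM in this assay. Within the data shown here, those two numbers lie within the usual scatter of each other, so neither compound can be set apart from the other on this evidence, and no step between them has been worked out. Compound 3 `CO[C@@H]1CC=C2N(c3ccccn3)C(=O)C[C@]2(c2ccccc2)O1` is the unmeasured analogue of compound 2, differing in one place: pyridin-2-yl in place of 4-methylphenyl on an amide-type nitrogen in a ring. Among the measured compounds shown here, no measured pair shows what such a swap does in this assay, so the step can only be judged in advance. The step expected from compound 2 to compound 3, a 1.1-fold higher number from compound 2 to compound 3 (0.06 log units; within the scatter), is small, with no direction beyond the scatter anticipated. Compound 3 is expected to give about 5000 nM in this assay, within a range from 2000 nM to 15000 nM.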

Compound 3, half-maximal inhibitory concentration: 8300 nM
Estimate against measurement, compound 3: 1.7-fold (0.22 log units) below; the measured number falls inside the stated range.
By their numbers in this assay, from the lowest: compounds 1, 2 and 3 (each within the scatter of the next, the first and the last beyond it).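

Among these compounds, on the amide-type nitrogen in a ring, pyridin-2-yl in place of 4-methylphenyl gives a 1.9-fold higher number from compound 2 to compound 3 (0.28 log units; within the scatter) in this assay, the first measured reading of any swap at this position. Compound 2 and compound 3 therefore cannot be set apart here, even though the entering ring carries a nitrogen and a hydrogen-bond acceptor that the leaving group lacks. No supporting measurement is available that could account for this result.

The compounds shown leave open whether a single swap at this nitrogen can move the number beyond the scatter, and whether an aromatic ring is needed there at all. Pyridin-3-yl, pyridin-4-yl, cyclohexyl or a plain methyl group on the same nitrogen would address those questions.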